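The source may hold more compounds than are shown below. What is called first, only, known or untested is meant among the compounds shown, and "the series" means these compounds.

Compounds in hand, with their readings in an assay on cells for inhibition of S-adenosylmethionine decarboxylase proenzyme (Homo sapiens), read by mass spectrometry, at pH 7.2; on this read-out higher numbers stand for weaker inhibition and lower numbers for stronger inhibition:

Compound 1, `Cc1cc(Nc2cc(Cl)cc(S(F)(F)(F)(F)F)c2)nc(N)n1`, gives > 180000 nM, which is a limit of the assay and not a number.
Compound 2, `Cc1cc(Nc2cc(Br)cc(S(F)(F)(F)(F)F)c2)nc(N)n1`, gives > 180000 nM, again a limit.
Compound 3, `CCCCOc1cc(Br)cc(Nc2cc(C)nc(N)n2)c1`, gives > 180000 nM, also a limit.

All three values sit at the limit of > 180000 nM in this assay, at which 3 of the 3 values shown sit. Going by the values given here, the two steps that connect them, a step that the two limits leave unreadable from compound 1 to compound 2 and a step that the two limits leave unreadable from compound 2 to compound 3, therefore have no readable size: each pair of limits tells only that neither compound reached a measurable inhibition.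

Compound 4, `Cc1cc(Nc2cccc(Cl)c2)nc(N)n1`, is the next compound for this assay. It differs from compound 1 by a hydrogen atom in place of a group of 6 heavy atoms (5 fluorine, 1 sulfur; no ring), on an aromatic carbon. The measured steps that bear on the shared core both start or end at a limit, so none of them shows whether removing a group from this position of the ring moves the read-out at all. The only thing the series shows is that compound 1, compound 2 and compound 3 all stay at the limit whatever group occupies that carbon.

Compound 4 is accordingly expected to stay at or near the same limit, with an estimated value of 200000 nM and a range of 40000 nM to 1000000 nM. The step that the limit leaves unreadable from compound 1 to compound 4 is expected to be none beyond the scatter, with a limit rather than a number the most likely outcome.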

Compound 4, half-maximal inhibitory concentration: > 180000 nM
Compound 4 ended at the assay's limit; the forecaster's own chance of this, stated with the estimate: 85%; the middle value does not contradict the limit.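

No new step can be read: compound 1 and compound 4 both give a limit and not a number, so the size of the change between them stays unknown, as for every compound here: the limit of > 180000 nM in this assay, at which 4 of the 4 values shown sit.

The compounds shown leave open whether any change to the shared core gives a measurable reading in this assay.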